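The source may hold more compounds than are shown below. What is called first, only, known or untested is meant among the compounds shown, and "the series" means these compounds.

Values in a functional assay on SK-OV-3 cells (Homo sapiens) for cytotoxicity, read by spectrophotometry, with a stated time of 72 h; on this read-out higher numbers stand for weaker inhibition and lower numbers for stronger inhibition:
- compound 1 `COc1ccc(-c2cccc(=O)n2-c2cc(OC)c(OC)c(OC)c2)cc1O`: < 10 nM (a limit of the assay, not a number)
- compound 2 `COc1ccc(-c2cccc(=O)n2-c2cc(OC)c(OC)c(OC)c2)cc1OC`: 545 nM
- compound 3 `COc1ccc(-c2cccc(=O)n2-c2cc(OC)c(OC)c(OC)c2)cc1C`: 583 nM
- compound 4 `COc1cc(-c2cccc(=O)n2-c2cc(OC)c(OC)c(OC)c2)cc(OC)c1OC`: not yet measured

Compound 2 cannot be separated from compound 3, with a 1.1-fold higher number from compound 2 to compound 3 (0.03 log units; within the scatter). Within the data shown here, the only other value is a limit, (the limit of < 10 nM in this assay, at which 1 of the 3 values shown sits).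

The step to follow changes compound 2 into compound 4: methoxy in place of hydrogen on an aromatic carbon. In words, this is methoxy in place of hydrogen on an aromatic carbon, ortho to a methoxy group.

Among the measured compounds shown here, no measured step makes this exact change, so the support is indirect. Two large steps show that the series responds to substitution in this region: an at least 54-fold higher number from compound 1 to compound 2 (1.73 log units; beyond the scatter) and an at least 58-fold higher number from compound 1 to compound 3 (1.76 log units; beyond the scatter). The swap of methoxy for methyl did much less, with a 1.1-fold higher number from compound 2 to compound 3 (0.03 log units; within the scatter). Compound 2 has already made the large step, so only a moderate further rise in this assay is expected, towards weaker inhibition. The estimated step is a 2.8-fold higher number from compound 2 to compound 4 (0.44 log units; beyond the scatter).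

For compound 4 the expected value is 1500 nM, with an estimated range of 400 nM to 6000 nM.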

Compound 4, half-maximal inhibitory concentration: 844 nM
Estimate against measurement, compound 4: 1.8-fold (0.25 log units) above; the measured number falls inside the stated range.
By their numbers in this assay, from the lowest: compounds 2, 3 and 4 (each within the scatter of the next). At a limit, below all of these: compound 1.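

In this assay, methoxy in place of hydrogen on an aromatic carbon, ortho to a methoxy group, gives a 1.5-fold higher number from compound 2 to compound 4 (0.19 log units; within the scatter), so this carbon accepts the added group with no change that can be told from the scatter. The earlier steps shown here only exchanged the group already carried at one site of this ring, whereas this step fills a carbon that holds hydrogen in compound 2. Among these compounds, compound 1 remains the only compound at a limit, which is not a number: the limit of < 10 nM in this assay, at which 1 of the 4 values shown sits.

As far as these compounds go, it remains open how an amine, a carboxylic acid or a longer chain such as ethoxy on this same carbon would read out. From the compounds shown here alone, it is also open whether a hydroxy in place of one methoxy of compound 4 would bring the series back to the limit seen for compound 1.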